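The source may report more compounds than this note shows. Statements on the series, on what has been measured and on what is new or still open speak of the compounds shown alone.

Of the compounds shown here, three built on a shared core have been tested in a toxicity assay on HepG2 cells (Homo sapiens) for inhibition, read by CellTiter-Glo, with a stated time of 48 h; on this read-out higher numbers stand for weaker inhibition and lower numbers for stronger inhibition. Compound 1 `COc1ccc2nc(C)cc(OC(C)C(=O)Nc3cc(C)cc(C)c3)c2c1` gives 39800 nM. Compound 2 `COc1ccc2nc(C)cc(OCC(=O)Nc3cccc(C)c3)c2c1` gives 39800 nM, level with compound 1 at the digits shown, a gap that lies within the usual scatter. Compound 3 `COc1ccc2nc(C)cc(OCC(=O)Nc3cc(OC)c(OC)c(OC)c3)c2c1` is recorded at > 100000 nM, which is a limit of the assay rather than a number; this is the limit of > 100000 nM in this assay, at which 1 of the 3 values shown sits. Compound 4 `COc1ccc2nc(C)cc(OCC(=O)Nc3nc(C)c(C)s3)c2c1` has not yet been measured. It differs from compound 2 in one place: 4,5-dimethyl-1,3-thiazol-2-yl in place of 3-methylphenyl on an amide-type nitrogen. Going by the values given here, no measured pair shows what this change does, so in this assay a step of no more than the scatter is expected, in no particular direction. Compound 4 is estimated at 40000 nM, from 15000 nM to 100000 nM. That estimate means a step of a 1.0-fold higher number from compound 2 to compound 4 (0.00 log units; within the scatter).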

Compound 4, half-maximal inhibitory concentration: > 100000 nM
Compound 4: no number, only a limit; the forecaster's own chance of this, stated with the estimate: 35%; at least 2.5-fold (0.39 log units) between middle value and limit.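

In this assay, going by these compounds alone, this is the first measured change on this amide-type nitrogen: 4,5-dimethyl-1,3-thiazol-2-yl in place of 3-methylphenyl brings an at least 2.5-fold higher number from compound 2 to compound 4 (0.40 log units; beyond the scatter). The swap therefore weakens inhibition of these cells, a larger effect than the small step expected. Compound 4 stands at a limit of the assay, not a number, so the full size of the step stays unknown: the limit of > 100000 nM in this assay, at which 2 of the 4 values shown sit.

From the compounds shown here alone, the swap replaces the ring and its methyl groups together, so their separate shares stay open. Also open, going by these compounds, is how an amine or a carboxylic acid in place of the methyl of 3-methylphenyl would read.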